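This account rests on a few compounds, and the source may have more. Where it says the series, first, only, none or still open, it means among the compounds named here.

In an ADME assay on cells (Macrophage, Homo sapiens) for cytotoxicity, read by MTT assay, with a stated time of 24 h (on this read-out higher numbers stand for lower toxicity in this test and lower numbers for higher toxicity in this test), compound 2 `CC(O)Cn1c([N+](=O)[O-])cnc1/C=C/c1ccc(Cl)cc1` gives 980 nM, the middle of three numbers and within the scatter of both others: compound 1 `COc1ccc(/C=C/c2ncc([N+](=O)[O-])n2CC(C)O)cc1` gives 560 nM and compound 3 `COc1cccc(/C=C/c2ncc([N+](=O)[O-])n2CC(C)O)c1` gives 1300 nM. Compound 4 `CC(O)Cn1c([N+](=O)[O-])cnc1/C=C/c1ccccc1Cl` has the same atoms as compound 2, joined differently: 2-chlorophenyl in place of 4-chlorophenyl on a double-bonded chain carbon bound to a double-bonded chain carbon. Within the data shown here, the only measured step that bears on this change, a 1.8-fold higher number from compound 1 to compound 2 (0.24 log units; within the scatter), exchanges one group for another and stays within the scatter. Among the measured compounds shown here, no measured step moves the chloro group itself, so the guidance is indirect. With that step as the guide, no change beyond the scatter is expected in this assay. The estimated 1.0-fold higher number from compound 2 to compound 4 (0.01 log units; within the scatter) is expected to be small. Compound 4 is estimated at 1000 nM, with an expected range from 450 nM to 2200 nM.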

Compound 4, half-maximal cytotoxic concentration: 480 nM
Estimate against measurement, compound 4: 2.1-fold (0.32 log units) above, and the stated range covers the measured number.
By their numbers in this assay, from the lowest: compounds 4, 1, 2 and 3 (each within the scatter of the next, the first and the last beyond it).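

In this assay, the move of the chloro group gives a 2.0-fold lower number from compound 2 to compound 4 (0.31 log units; beyond the scatter), a modest step and the first shown here to lie beyond the scatter. On this read-out the lower number stands for higher toxicity in this test, so 2-chlorophenyl and 4-chlorophenyl at this place can be told apart, which the exchange of groups in the earlier step, within the scatter, did not show. Nothing available explains this difference. The compounds shown leave open whether a bromo group or a fluoro group in place of chloro would show the same difference between these two arrangements. They also leave open how an amine or a carboxylic acid on the phenyl ring would read.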